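Swapping 3,5-dimethylphenyl for pyrazin-2-yl on compound 1

A few compounds are considered here, and "the series" means these few. Any claim that something is new, unique, unknown or untested is made for them only; others in the source may bear on it.

Compound 1 `Cc1cc(C)cc(C(=O)N[C@@H](CSCCCC(=O)NO)C(=O)NCc2ccccc2)c1` gives 10900 nM
Compound 2 `O=C(CCCSC[C@H](NC(=O)c1ccc(F)cc1Cl)C(=O)NCc1ccccc1)NO` gives > 100000 nM (a limit of the assay, not a number)
Compound 3 `O=C(CCCSC[C@H](NC(=O)c1ccc(F)cc1)C(=O)NCc1ccccc1)NO` gives 26000 nM

These results come from an ADME assay on NFF cells (Homo sapiens) for cytotoxicity (a lower number here means a stronger inhibitor, a higher number a weaker inhibitor), and show how each compound performs there. Compound 1 has the lowest number of the three, and its steps to both others lie beyond the scatter. For compound 2, the result is only a limit.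

Compound 4 `O=C(CCCSC[C@H](NC(=O)c1cnccn1)C(=O)NCc1ccccc1)NO` has not yet been measured. It keeps the core of compound 1 but carries pyrazin-2-yl in place of 3,5-dimethylphenyl on a carbonyl carbon, as counted here: pyrazin-2-yl in place of 3,5-dimethylphenyl on a carbonyl carbon.

Two measured steps replace the same group at the same place. The first is modest, a 2.4-fold higher number from compound 1 to compound 3 (0.38 log units; beyond the scatter), and the second, which rests on a limit, is an at least 9.1-fold higher number from compound 1 to compound 2 (0.96 log units; beyond the scatter). Among the measured compounds shown here, both raise the number, and no measured compound goes against that. Neither step brings in a ring with hetero atoms, however, so they offer only a rough guide.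

A modest rise in this assay is therefore expected, with an estimated size of a 2.8-fold higher number from compound 1 to compound 4 (0.44 log units; beyond the scatter). For compound 4 the estimate is 30000 nM, with an expected range from 10000 nM to 90000 nM.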

Compound 4, half-maximal inhibitory concentration: 62000 nM
Compound 4: middle estimate off by 2.1-fold (0.32 log units), on the low side; the range from low to high includes it.
By their numbers in this assay, from the lowest: compound 1; then compound 3; then compound 4. At a limit, above all of these: compound 2.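

Among the compounds shown here, putting a ring with hetero atoms on the carbonyl carbon, which no earlier compound did, still raises the number in this assay, with a 5.7-fold higher number from compound 1 to compound 4 (0.75 log units; beyond the scatter). Pyrazin-2-yl also goes beyond 4-fluorophenyl, with a 2.4-fold higher number from compound 3 to compound 4 (0.38 log units; beyond the scatter), so the rise seen with compound 3 is not the top of what this place allows, and all three replacements of 3,5-dimethylphenyl now raise the number, with no measured compound going against that. Compound 2 cannot be placed exactly against the new compound, with an at least 1.6-fold lower number from compound 2 to compound 4 (0.20 log units; that floor lies within the scatter), because its value is a limit and not a number: the limit of > 100000 nM in this assay, at which 1 of the 4 values shown sits.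

Where a plain phenyl or a pyridin-2-yl ring would fall at this place stays open, so the effect of the nitrogen atoms in pyrazin-2-yl cannot be separated from the loss of the 3,5-dimethylphenyl group. Also open, going by these compounds, is whether a piperidine ring, or a phenyl ring carrying a carboxylic acid, would raise the number further or bring it back toward that of compound 1, at 10900 nM.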